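The source may hold more compounds than are shown below. What is called first, only, known or untested is meant among the compounds shown, and "the series" means these compounds.

Compound 1 `CC(C)N(Cc1cccc(OCCCCCC(=O)O)c1)C(=O)c1ccc(-c2cccc(N(C)C)c2)cc1`: in an ADME assay on Raji cells (Homo sapiens) for cytotoxicity, read by CellTiter-Glo and resazurin assay, with a stated time of 72 h (on this read-out higher numbers stand for an effect only at larger amounts of compound and lower numbers for an effect already at smaller amounts), compound 1 gives > 26000 nM, which is a limit of the assay rather than a number.
Compound 2 `CC(C)N(Cc1cccc(OCCCCCC(=O)O)c1)C(=O)c1ccc(-c2ccc3c(c2)OCCO3)cc1`: in this assay compound 2 gives > 21900 nM, again a limit.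
Compound 3 `CCOC(=O)CCCCCOc1cccc(CN(C(=O)c2ccc(-c3cccnc3)cc2)C(C)C)c1`: in this assay compound 3 gives > 26000 nM, also a limit.

Every value so far is a limit, so none of these compounds showed a measurable effect on the cells within the tested range. Among the compounds with values here, the only step between two compounds that differ in one place, 2,3-dihydro-1,4-benzodioxin-6-yl in place of 3-(dimethylamino)phenyl on an aromatic carbon, reads a step that the two limits leave unreadable from compound 1 to compound 2; its size cannot be read because both ends sit at limits (the limit of > 21900 nM in this assay, at which 1 of the 3 values shown sits, (the limit of > 26000 nM in this assay, at which 2 of the 3 values shown sit)). Compound 3 stands at the limit of > 26000 nM in this assay, at which 2 of the 3 values shown sit, the upper edge of what was measured.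

Compound 4 `CCOC(=O)CCCCCOc1cccc(CN(C(=O)c2ccc(-c3cccc(F)c3)cc2)C(C)C)c1` differs from compound 3 by 3-fluorophenyl in place of pyridin-3-yl on an aromatic carbon. No measured step speaks to this change, and the one step shown is unreadable, so no shift beyond the usual scatter is expected. Compound 4 is therefore expected to give 40000 nM, within an estimated range from 15000 nM to 120000 nM. The estimated step that the limit leaves unreadable from compound 3 to compound 4 is expected to lie within the scatter, most likely again as a limit.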

Compound 4, half-maximal effective concentration: > 26000 nM
Compound 4 ended at the assay's limit; the forecaster's own chance of this, stated with the estimate: 85%; the middle value lies beyond the limit too.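

Compound 3 and compound 4 both end at a limit in this assay rather than at a number, so the step between them cannot be read. The compounds shown leave open whether any of these structures has a measurable effect on the cells, and how much swapping a group would change it.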